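This account rests on a few compounds, and the source may have more. Where it says the series, first, only, none or still open, it means among the compounds named here.

Three members of this set have so far been tested in a functional assay on HL-60 cells (Homo sapiens) for cytotoxicity, read by luminescence and CellTiter-Glo, with a stated time of 3 days; a higher number here means a weaker inhibitor, a lower number a stronger inhibitor. Compound 1 `O=C(Nc1ccc(Br)c(Cl)c1)c1cc(F)ccc1O` gives 600 nM in this assay. Compound 3 `O=C(Nc1ccc(Cl)c(C(F)(F)F)c1)c1cc(F)ccc1O` gives 600 nM in this assay, which stands level with compound 1 at the digits shown, so the two lie within the usual scatter of each other and no order can be read between them. Compound 2 `O=C(Nc1ccccc1)c1cc(F)ccc1O` reaches only a limit in this assay, > 10000 nM, and that is the limit of > 10000 nM in this assay, at which 1 of the 3 values shown sits.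

Compound 4 `O=C(Nc1ccc(Cl)c(Cl)c1)c1cc(F)ccc1O` has not yet been measured. It differs from compound 3 in a single place: chloro in place of trifluoromethyl on an aromatic carbon. Since compound 1 and compound 3, which carry different groups on that ring, give values that do not differ beyond the scatter, the substitution of chloro for trifluoromethyl is expected to leave the potency essentially where compound 3 sits, with no step beyond the scatter in either direction. The change that this expectation means is no change at the digits printed from compound 3 to compound 4 (within the scatter). Compound 4 is therefore estimated to give about 600 nM in this assay, with a plausible range from 250 nM to 1500 nM.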

Compound 4, half-maximal inhibitory concentration: 660 nM
The estimate for compound 4 lay 1.1-fold (0.04 log units) below the measured number, within the range that was stated.
By their numbers in this assay, from the lowest: compounds 1, 3 and 4 (each within the scatter of the next). At a limit, above all of these: compound 2.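

In this assay, compound 1 and compound 3 differed in two places, so their matching values said nothing about either place alone, whereas compound 4 now links each of them to the set by a single change. On the aromatic carbon ortho to a chloro group and meta to a large group, trifluoromethyl, with its 4 heavy atoms, gives way to chloro, with 1 heavy atom, and the result is a 1.1-fold higher number from compound 3 to compound 4 (0.04 log units; within the scatter); on another aromatic carbon, chloro in place of bromo gives a 1.1-fold higher number from compound 1 to compound 4 (0.04 log units; within the scatter), so neither exchange separates the compounds in this assay. Nothing shown offers a measured cause for this, and the one limit in the set, that of compound 2, belongs to a compound that differs from compound 4 in more than one place.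

The compounds shown carry only halogen or trifluoromethyl at these two carbons, so it remains open how a methoxy group, an amine, a carboxylic acid or a longer chain would read there. Also open, as far as these compounds go, is what hydrogen would give in place of either group alone, with the other kept.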